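This account rests on a few compounds, and the source may have more. Where it says the series, first, only, none or still open, it means among the compounds named here.

Two compounds of the series carry a number in a functional assay on cells for positive allosteric modulation of G-protein coupled receptor 68 (Homo sapiens), read by a luciferase reporter and cAMP accumulation, with a stated time of 30 min, at pH 6.8 and pH 8.3, in the presence of a further agent that is not named here; a higher number here means a more potent compound, by a factor of ten per unit of this negative logarithm, a lower number a less potent compound. Compound 1 `Nc1nc(NCc2ccccc2)nc(-c2cc(Cl)ccc2CO)n1` gives 4.49 there, and compound 2 `Nc1nc(NCc2ccc(Oc3ccccc3)cc2)nc(-c2ccccc2CO)n1` gives 5.19, the higher of the two by a gap beyond the scatter. Compound 3 `Nc1nc(NCc2ccc(Oc3ccccc3)cc2)nc(-c2cc(Cl)ccc2CO)n1` is compound 2 with chloro in place of hydrogen on an aromatic carbon. Going by the values given here, no measured pair differs in this one place alone, so the size of the step cannot be read from the series; compound 1 also carries the chloro group but differs elsewhere as well. The step is expected to be small, within the scatter in either direction, at a number 0.01 log units higher from compound 2 to compound 3 (within the scatter). Compound 3 is estimated at 5.2, between 4.6 and 5.8.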

Compound 3, negative logarithm of the antagonist equilibrium constant: 4.7
The estimate for compound 3 lay 0.50 log units above the measured number; the range from low to high includes it.
By their numbers in this assay, from the lowest: compounds 1 and 3 (each within the scatter of the next); then compound 2.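

With the phenoxy group present in this assay, chloro para to the hydroxymethyl group is not a neutral change, giving a number 0.49 log units lower from compound 2 to compound 3 (beyond the scatter). With the chloro group held in place, the phenoxy group gives a number 0.21 log units higher from compound 1 to compound 3 (within the scatter), so the two compounds carrying chloro are not separated in this assay. No data at hand bear on the reason for either step.

Going by these compounds, whether an amine or a methoxy group in that same place would follow chloro remains open. So does the size of the chloro step in the absence of the phenoxy group.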